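Removing the ring chlorine from compound 2

This account rests on a few compounds, and the source may have more. Where it says the series, first, only, none or still open, it means among the compounds named here.

In a functional assay on HEp-2 cells (Homo sapiens) for inhibition, read by sulforhodamine B assay, with a stated time of 48 h, tested at 100 uM (on this read-out lower numbers stand for less inhibition of growth and higher numbers for more inhibition of growth at the one concentration tested), compound 2 `O=c1c(C2N=C(c3ccccc3)SS2)coc2ccc(Cl)cc12` gives 69%, the highest of the three measured values. Compound 1 `Cc1ccc2occ(C3N=C(c4ccccc4)SS3)c(=O)c2c1` gives 43% and compound 3 `O=c1c(C2N=C(c3ccccc3)SS2)coc2cc(Cl)c(Cl)cc12` gives 51%. Compound 4 `O=c1c(C2N=C(c3ccccc3)SS2)coc2ccccc12` differs from compound 2 by hydrogen in place of chloro on an aromatic carbon. For the measured compounds named here, no measured step exchanges chloro for hydrogen at this position; the nearest are a number 26 percentage points higher from compound 1 to compound 2 (beyond the scatter) and a number 18 percentage points lower from compound 2 to compound 3 (beyond the scatter), both modest and beyond the scatter. The first shows that methyl to chloro at this position raised the number; the second that a further chloro on the ring lowered it. Losing the chloro is therefore expected to give a modest drop beyond the scatter in this assay, a number 19 percentage points lower from compound 2 to compound 4 (beyond the scatter). Compound 4 is estimated at 50%, range 32% to 68%.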

Compound 4, percent growth inhibition at one concentration: 48%
The estimate for compound 4 lay 2 percentage points above the measured number; the measured number falls inside the stated range.
By their numbers in this assay, from the lowest: compounds 1, 4 and 3 (each within the scatter of the next); then compound 2.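

In this assay, hydrogen now gives a baseline for this position: a number 21 percentage points lower from compound 2 to compound 4 (beyond the scatter), so the chloro of compound 2 accounts for a real gain over the unsubstituted ring. Methyl does not share that gain, with a number 5 percentage points higher from compound 1 to compound 4 (within the scatter), so of the three groups at this aromatic carbon only chloro stands apart. Nothing available explains why chloro differs from methyl and hydrogen here. On these data alone, whether fluoro, bromo or an amine on this carbon would match chloro remains open.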